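Swapping the aryl group on a shared core

The source may report more compounds than this note shows. Statements on the series, on what has been measured and on what is new or still open speak of the compounds shown alone.

In a functional assay, tested at 50 ug/mL (on this read-out higher numbers stand for a stronger effect at the one concentration tested and lower numbers for a weaker effect), compound 1 `Cc1ccccc1C1C(C#N)=C(N)OC(c2c[nH]c3ccccc23)=C1C#N` gives 10.4%, and compound 2 `COc1ccc(C2C(C#N)=C(N)OC(c3c[nH]c4ccccc34)=C2C#N)cc1` gives 12.4%. Compound 2 holds the higher of the two measured numbers, but since the step of a number 2 percentage points higher from compound 1 to compound 2 (within the scatter) lies within the scatter, the two compounds cannot be told apart. Compound 3 `N#CC1=C(N)OC(c2c[nH]c3ccccc23)=C(C#N)C1c1ccccc1Cl` carries 2-chlorophenyl in place of 4-methoxyphenyl on a saturated ring carbon. Among the compounds with values here, the only measured step that bears on this change is the earlier swap of one aromatic group for another on that same saturated ring carbon, which moved the read-out by a number 2 percentage points higher from compound 1 to compound 2 (within the scatter). No step beyond the scatter is therefore expected, and compound 3 is estimated at 11%, within 2% to 22%, which means an expected step of a number 1.4 percentage points lower from compound 2 to compound 3 (within the scatter).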

Compound 3, a percentage reported as activity, at one concentration (the size of the read-out at that concentration, not a potency): 8.5%
Estimate against measurement, compound 3: 2.5 percentage points above, and the stated range covers the measured number.
By their numbers in this assay, from the lowest: compounds 3, 1 and 2 (each within the scatter of the next).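

In this assay, the step of a number 3.9 percentage points lower from compound 2 to compound 3 (within the scatter) for 2-chlorophenyl in place of 4-methoxyphenyl and the step of a number 1.9 percentage points lower from compound 1 to compound 3 (within the scatter) for chloro in place of methyl on the aromatic ring both show no real difference. An aromatic group carrying chlorine on this saturated ring carbon therefore cannot be told apart from those carrying methyl or methoxy. Nothing available gives a reason for these numbers. As far as these compounds go, what a group that is not aromatic, such as an amine or a carboxylic acid, would do on this carbon stays open.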